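Replacing Isopropyl with 3-(Diethylamino)propyl

A few compounds are considered here, and "the series" means these few. Any claim that something is new, unique, unknown or untested is made for them only; others in the source may bear on it.

Measured in a functional assay on DU-145 cells (Homo sapiens) for antiproliferative activity, read by WST assay, with a stated time of 3 days; a higher number here means a weaker inhibitor, a lower number a stronger inhibitor:
- Compound 1 `CCCCCCOc1c(-c2cc(OC)c(OC)c(OC)c2)oc2ccccc2c1=O`: > 50000 nM, a limit of the assay
- Compound 2 `COc1cc(-c2oc3ccccc3c(=O)c2OC(C)C)cc(OC)c1OC`: > 50000 nM, a limit of the assay

Compound 2 has no number, only a limit in this assay. The one other result is also a limit, and (the limit of > 50000 nM in this assay, at which 2 of the 2 values shown sit).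

The next compound is compound 3 `CCN(CC)CCCOc1c(-c2cc(OC)c(OC)c(OC)c2)oc2ccccc2c1=O`, and the change is 3-(diethylamino)propyl in place of isopropyl on an oxygen on an aromatic ring. In words, 3-(diethylamino)propyl stands in place of isopropyl on an oxygen on an aromatic ring.

For the measured compounds named here, one measured step bears on this change, a step that the two limits leave unreadable from compound 1 to compound 2. It has no readable size, so it cannot set the size of the new step. The new group differs from both hexyl and isopropyl, so a modest move towards a stronger inhibitor is expected, though compound 3 may also end at a limit.

The expected step is an at least 2.0-fold lower number from compound 2 to compound 3 (0.30 log units; that floor lies within the scatter).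

For compound 3 the estimated value is 25000 nM, with an expected range of 8000 nM to 60000 nM.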

Compound 3, half-maximal inhibitory concentration: > 50000 nM
Compound 3: only a limit was reported (the forecaster's own chance of this, stated with the estimate: 40%); at least 2.0-fold (0.30 log units) between middle value and limit.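

In this assay compound 3 ends at a limit, as do compound 1 and compound 2, so no step among these three compounds can be read: the limit of > 50000 nM in this assay, at which 3 of the 3 values shown sit. The compounds shown leave open whether hexyl, isopropyl and 3-(diethylamino)propyl differ at all in this read-out.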